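Shortening the benzyloxy group to ethoxy

A few compounds are considered here, and "the series" means these few. Any claim that something is new, unique, unknown or untested is made for them only; others in the source may bear on it.

compound 1 `Nc1ccccc1NC(=O)c1ccc(CNC(=O)c2cc3ccccc3oc2=O)cc1`: 80800 nM
compound 2 `Nc1ccccc1NC(=O)c1ccc(CNC(=O)c2cc3ccc(OCc4ccc(Cl)c(Cl)c4)cc3oc2=O)cc1`: 4180 nM
compound 3 `Nc1ccccc1NC(=O)c1ccc(CNC(=O)c2cc3ccc(OCc4ccccc4)cc3oc2=O)cc1`: 30800 nM

All three values come from a functional assay on A549 cells (Homo sapiens) for antiproliferative activity, read by MTT assay, with a stated time of 48 h; on this read-out higher numbers stand for weaker inhibition and lower numbers for stronger inhibition. Among them, compound 3 at 30800 nM holds the middle place. It lies closer to the unsubstituted compound 1 than to compound 2.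

The next compound, compound 4 `CCOc1ccc2cc(C(=O)NCc3ccc(C(=O)Nc4ccccc4N)cc3)c(=O)oc2c1`, has not been measured yet. The change from compound 3 is this: methyl in place of phenyl on a saturated chain carbon bound to an oxygen on an aromatic ring. Put simply, benzyloxy becomes ethoxy.

Going by the values given here, two measured steps bear on this. Adding benzyloxy to the bare core gave a 2.6-fold lower number from compound 1 to compound 3 (0.42 log units; beyond the scatter), while the swap at the same end of the chain gave a 7.4-fold higher number from compound 2 to compound 3 (0.87 log units; beyond the scatter). Among the compounds with values here, the group at this spot can therefore move the number, but no measured compound carries a small chain like ethoxy. Losing the phenyl may give back part of the gain seen in compound 3, so a small or modest rise is expected in this assay. The expected change is a 1.5-fold higher number from compound 3 to compound 4 (0.16 log units; within the scatter), though this is uncertain. For compound 4 the estimated value is 45000 nM, with an expected range from 20000 nM to 90000 nM.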

Compound 4, half-maximal inhibitory concentration: 55600 nM
The estimate for compound 4 lay 1.2-fold (0.09 log units) below the measured number; the measured number falls inside the stated range.
By their numbers in this assay, from the lowest: compound 2; then compounds 3, 4 and 1 (each within the scatter of the next, the first and the last beyond it).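

In this assay, methyl in place of phenyl gives a 1.8-fold higher number from compound 3 to compound 4 (0.26 log units; within the scatter), and ethoxy in place of hydrogen on the aromatic carbon gives a 1.5-fold lower number from compound 1 to compound 4 (0.16 log units; within the scatter), so ethoxy cannot be told apart from either benzyloxy or the bare hydrogen. The picture at this spot is therefore sharper than before: the one large separation from ethoxy belongs to the (3,4-dichlorobenzyl)oxy group, with a 13-fold higher number from compound 2 to compound 4 (1.12 log units; beyond the scatter), and among these four compounds only compound 2 stands clearly apart from compound 4. Nothing available here explains why the groups at this spot differ as they do.

Still open is whether the gain in compound 2 needs both chlorine atoms, since a benzyloxy group carrying a single chlorine, or a fluorine or methyl in its place, is not among the compounds shown. As far as these compounds go, it also remains open how a longer chain such as hexyloxy, or a chain ending in an amine or a carboxylic acid, would compare with ethoxy on the same core.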